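Swapping a chlorobenzyl amine for a dimethylmorpholine chain end

A few compounds are considered here, and "the series" means these few. Any claim that something is new, unique, unknown or untested is made for them only; others in the source may bear on it.

In a physicochemical assay for acid dissociation, compound 1 `Cc1csc2cc([C@H](C)Nc3ncnc(N)c3C#N)c(-c3cccc(CN(C)CCCN(C)Cc4ccc(Cl)cc4)c3)c(=O)n12` gives 7.5 and so stands highest of the two numbers available. Compound 2 `Cc1csc2cc([C@H](C)Nc3ncnc(N)c3C#N)c(-c3cccc(CN4CCC(N(C)CCC(F)(F)F)CC4)c3)c(=O)n12` gives 6 as the lower number, and the gap between the two lies beyond the scatter. Compound 3 `Cc1csc2cc([C@H](C)Nc3ncnc(N)c3C#N)c(-c3cccc(CN(C)CCCCN4C[C@@H](C)O[C@@H](C)C4)c3)c(=O)n12` has not yet been measured. Going by the values given here, the change (2,6-dimethylmorpholin-4-yl)methyl in place of (4-chlorobenzyl)(methyl)amino on a saturated chain carbon, three bonds along the chain from an amine nitrogen is the only one separating compound 3 from compound 1. Among the compounds with values here, no measured pair shows this change alone, and compound 1 and compound 2 differ in more than one place, so their gap cannot simply be carried over. In this assay only a slight upward move is expected, with nothing beyond the scatter. The expected step is a number 0.10 log units higher from compound 1 to compound 3 (within the scatter) and it remains small. For compound 3 the estimated value is 7.6 with an expected range from 7 to 8.2 on the same scale.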

Compound 3, acid dissociation constant: 6.3
For compound 3 the middle estimate is 1.30 log units above the measured one; the whole stated range lies above it.
By their numbers in this assay, from the lowest: compounds 2 and 3 (each within the scatter of the next); then compound 1.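

In this assay, going by these compounds alone, placing (2,6-dimethylmorpholin-4-yl)methyl in place of (4-chlorobenzyl)(methyl)amino on a saturated chain carbon, three bonds along the chain from an amine nitrogen, gives the first reading of this change on its own. The step is a number 1.20 log units lower from compound 1 to compound 3 (beyond the scatter) and it is large, so the read-out of these compounds does respond to what stands at this chain end. Nothing in the data shown bears on why the number moves.

Still open, from the compounds shown here alone, is which part of the change carries the step, since the chlorinated benzene ring leaves and the dimethylmorpholine ring enters in the same swap. A plain morpholine or an unchlorinated benzylamine at this chain end would help to separate the two.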